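Compound 3 to compound 4: adding diethylamino

The compounds below may be only part of what the source reports. "The series", "measured", "known", "first", "only" and "open" are said of these compounds alone.

In a functional assay on HepG2 cells (Homo sapiens) for cytotoxicity, read by MTT assay, with a stated time of 48 h (on this read-out higher numbers stand for weaker inhibition and lower numbers for stronger inhibition), compound 3 (`Cc1ccc2c(=O)cc(-c3ccccc3Cl)oc2c1`) gives 28300 nM as the highest of the two numbers available. Compound 1 (`Cc1ccc2oc(-c3ccccc3Cl)cc(=O)c2c1`) gives 6230 nM on the same read-out, a lower number by more than the usual scatter. Compound 2 (`CN(C)Cc1ccc2oc(-c3ccc([N+](=O)[O-])cc3)cc(=O)c2c1`) adds no number to the series, its entry being "not determined" (no result reported) in this assay here.

Compound 4 (`CCN(CC)Cc1ccc2c(=O)cc(-c3ccccc3Cl)oc2c1`) differs from compound 3 by diethylamino in place of hydrogen on a saturated chain carbon bound to an aromatic carbon with diethylamino in place of hydrogen on a saturated chain carbon bound to an aromatic carbon. Among the measured compounds shown here, no pair of measured compounds shows the size of such a change, so the expectation is loose. For the measured compounds named here, the only anchor is compound 3 at 28300 nM as the starting point at the weak end of the numbers. A move beyond the scatter toward stronger inhibition is expected, with a 2.6-fold lower number from compound 3 to compound 4 (0.41 log units; beyond the scatter) as the estimated step. For compound 4 the estimated value is 11000 nM with an expected range of 3500 nM to 32000 nM for now.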

Compound 4, half-maximal inhibitory concentration: 10700 nM
Estimate against measurement, compound 4: 1.0-fold (0.01 log units) above; low and high end bracket the measured number.
By their numbers in this assay, from the lowest: compounds 1 and 4 (each within the scatter of the next); then compound 3.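

In this assay, among the compounds shown here, the change from methyl to (diethylamino)methyl gives a 2.6-fold lower number from compound 3 to compound 4 (0.42 log units; beyond the scatter), the first step between compounds that differ in one place. It shows that diethylamino can stand on this saturated chain carbon bound to an aromatic carbon without loss of measurable inhibition, and that the number moves toward stronger inhibition by a modest step that still lies beyond the scatter. No supporting data bear on what lies behind this step.

Open, on these data alone, is whether a morpholine or a primary amine at this place, or a carboxylic acid on the chain, would move the number as diethylamino does. Also open, as far as these compounds go, is whether the same change on the core of compound 1 would give a step of similar size.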